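A trifluoromethoxyphenyl variant of an aminothiophene piperazine series

The compounds below may be only part of what the source reports. "The series", "measured", "known", "first", "only" and "open" are said of these compounds alone.

Compound 1, with the structure `Nc1scc(CN2CCN(c3ccc(Cl)cc3Cl)CC2)c1C(=O)c1ccc(Cl)cc1`, and compound 2, with the structure `Nc1scc(CN2CCN(c3ccccc3C(F)(F)F)CC2)c1C(=O)c1ccc(Cl)cc1`, share one core and differ only in the aryl group on the piperazine nitrogen. In a functional assay on CHO cells with adenosine receptor A1 (Homo sapiens) as the target, read by cAMP accumulation and immunoassay, with a stated time of 6 min, tested at 10 uM (a higher number here means a weaker effect of the compound at the concentration tested, a lower number a stronger effect), compound 1 gives -74%, while compound 2 gives -60%. Among the compounds with values here, the single step known, a number 14 percentage points higher from compound 1 to compound 2 (beyond the scatter), places compound 2 as the higher of the two numbers, the nearest value being that of compound 1.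

Compound 3, with the structure `Nc1scc(CN2CCN(c3ccc(OC(F)(F)F)cc3)CC2)c1C(=O)c1ccc(Cl)cc1`, is not yet measured. Relative to compound 2 it carries 4-(trifluoromethoxy)phenyl in place of 2-(trifluoromethyl)phenyl on an amine nitrogen in a ring. Within the data shown here, the only step that bears on this change is the one between compound 1 and compound 2, which swapped another aryl group at the same ring nitrogen and moved the value by a modest amount. With so little to go on, the expected step of a number 5 percentage points lower from compound 2 to compound 3 (within the scatter) is small and could fall on either side of the scatter. Compound 3 is therefore estimated to give -65% in this assay, with a range from -85% to -40%.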

Compound 3, a percentage reported as activity, at one concentration (the size of the read-out at that concentration, not a potency): -74%
Beside the measured number, compound 3's estimate is 9 percentage points above it; measured number inside the range.
By their numbers in this assay, from the lowest: compounds 1 and 3 (each within the scatter of the next); then compound 2.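

In this assay, the step of a number 14 percentage points lower from compound 2 to compound 3 (beyond the scatter) shows that the read-out at this amine nitrogen in a ring responds to a second aryl exchange, this time with an oxygen-bearing group, 4-(trifluoromethoxy)phenyl, replacing 2-(trifluoromethyl)phenyl. The step of no change at the digits printed from compound 1 to compound 3 (within the scatter) adds what the first pair could not show: two different aryl groups, 2,4-dichlorophenyl and 4-(trifluoromethoxy)phenyl, cannot be told apart here, and compound 2 alone stands apart, the only one of the three whose aryl group has no substituent named at position 4. Nothing available explains this grouping of three compounds, which remains a description of them and no more.

Open, going by these compounds, is whether a 4-chlorophenyl, a 4-methoxyphenyl or an unsubstituted phenyl on the same nitrogen would fall with compounds 1 and 3 or with compound 2, which would test whether the grouping holds beyond these compounds. Since each value comes from a single concentration, these compounds also leave open how their potencies compare.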